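The source may hold more compounds than are shown below. What is called first, only, known or untested is meant among the compounds shown, and "the series" means these compounds.

Three measured compounds share one core. Compound 1 `Clc1ccc(COc2ccccc2/C=C/C(/C=C/c2ccccn2)=N/Oc2ncnc3cc(Cl)ccc23)c(Cl)c1` gives 91.8% in a functional assay on SMMC-7721 cells (Homo sapiens) for inhibition, read by MTT assay, with a stated time of 72 h, tested at 10 uM; on this read-out higher numbers stand for a stronger effect at the one concentration tested and lower numbers for a weaker effect. Compound 2 `Clc1ccccc1COc1ccccc1/C=C/C(/C=C/c1ccccn1)=N/Oc1ncnc2ccccc12` gives 96% in this assay. Compound 3 `Clc1ccc2c(O/N=C(\C=C\c3ccccn3)/C=C/c3ccccc3OCc3ccccc3Cl)ncnc2c1` gives 94.5% in this assay, the second highest of the three numbers, with compound 2 nearest and compound 1 furthest, both within the scatter. Among the measured compounds shown here, the two measured steps, a number 2.7 percentage points higher from compound 1 to compound 3 (within the scatter) and a number 1.5 percentage points lower from compound 2 to compound 3 (within the scatter), each concern chloro against hydrogen on an aromatic carbon of the core and each stayed within the scatter, so the numbers so far hardly move with such a swap. Compound 4 `Clc1ccc(COc2ccccc2/C=C/C(/C=C/c2ccccn2)=N/Oc2ncnc3cc(Cl)ccc23)cc1` differs from compound 3 by 4-chlorophenyl in place of 2-chlorophenyl on a saturated chain carbon bound to an oxygen on an aromatic ring. For the measured compounds named here, no measured step touches the move from 2-chlorobenzyl to 4-chlorobenzyl, so the only guide is that every measured number sits close to the others. Compound 4 is therefore expected to show a step of a number 1.5 percentage points lower from compound 3 to compound 4 (within the scatter), nothing beyond the scatter. Compound 4 is estimated at 93%, within a range from 84% to 99%.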

Compound 4, a percentage reported as inhibition, at one concentration (the size of the read-out at that concentration, not a potency): 94.8%
For compound 4 the middle estimate is 1.8 percentage points below the measured one, and the stated range covers the measured number.
By their numbers in this assay, from the lowest: compounds 1, 3, 4 and 2 (each within the scatter of the next).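

In this assay, among the compounds shown here, the first measured change at this place, 4-chlorophenyl in place of 2-chlorophenyl on a saturated chain carbon bound to an oxygen on an aromatic ring, gives a number 0.3 percentage points higher from compound 3 to compound 4 (within the scatter), so where the chloro sits on this benzyl group makes no readable difference here. Taking a chloro off this same group, with hydrogen in its place on an aromatic carbon, gives a number 3 percentage points higher from compound 1 to compound 4 (within the scatter). The chloro and hydrogen swap can now be read on two cores, and the two readings agree: the same change on two cores in this assay, a number 1.5 percentage points lower (within the scatter) from compound 2 to compound 3 and a number 3 percentage points lower (within the scatter) from compound 4 to compound 1, 1.5 percentage points apart, within the scatter of two such steps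

With one tested concentration and every number close to the next, the compounds shown give no order of potency. Going by these compounds, whether an amine or a carboxylic acid in place of the chloro, or a longer chain in place of the benzyl group, would shift the number remains open.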